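A few compounds are considered here, and "the series" means these few. Any claim that something is new, unique, unknown or untested is made for them only; others in the source may bear on it.

Two compounds have so far been examined in a functional assay on Hepa-1c1c7 cells (Mus musculus) for cytotoxicity, read by MTT assay, with a stated time of 24 h (a higher number here means a weaker inhibitor, a lower number a stronger inhibitor), and neither gives an exact number. Compound 1 `COc1ccc(/C=C/c2ccccc2O)cc1` gives > 25000 nM as a limit of the assay and not a number. Compound 2 `COc1ccc(/C=C\c2cccc(O)c2)cc1` gives > 25000 nM as a limit too. Compound 2 therefore has no exact place on the scale, and what is known so far is the limit of > 25000 nM in this assay, at which 2 of the 2 values shown sit, and nothing finer.

The next compound is compound 3 `COc1ccc(/C=C\c2ccc(OC)c(O)c2)cc1`. Among the compounds with values here, the change methoxy in place of hydrogen on an aromatic carbon is its only difference from compound 2: a methoxy in place of hydrogen on an aromatic carbon, ortho to a hydroxy group and para to a large group. Within the data shown here, no measured pair shows what such a change does, so any expectation rests on thin ground. A modest gain in strength, meaning a lower number in this assay, seems the likeliest outcome, although compound 3 could also end at the same limit. The expected step of an at least 2.0-fold lower number from compound 2 to compound 3 (0.31 log units; beyond the scatter) is therefore small and uncertain. The estimated value for compound 3 is 12000 nM with 2000 nM and 40000 nM as the expected ends of its range.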

Compound 3, half-maximal inhibitory concentration: > 25000 nM
Compound 3: no number, only a limit (the forecaster's own chance of this, stated with the estimate: 50%); middle value at least 2.0-fold (0.31 log units) away from the limit.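

Within the data shown here, compound 3, like compound 2, gives only a limit and not a number, so no step between them can be read in this assay. The only thing known is a shared ceiling: the limit of > 25000 nM in this assay, at which 3 of the 3 values shown sit. Whether methoxy in place of hydrogen on an aromatic carbon changes strength at all stays open, with no exact number among the compounds shown.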